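The compounds below may be only part of what the source reports. "The series", "measured", "known", "first", "only" and "open" are said of these compounds alone.

Among the measured compounds shown here, compound 1 `O=C1CC(C(F)(F)F)CN1c1cnn2c1CN(C(=O)Nc1cc(F)c(F)c(F)c1)C(C1CC1)C2` is tested in a toxicity assay on HepG2 2.2.15 cells (Homo sapiens) for cytotoxicity, read by CellTiter-Glo (a higher number here means that more compound is tolerated, a lower number that less compound is tolerated), and gives 115000 nM, the only number recorded there. In this assay compound 2 `CC1(C)CN(C(=O)Nc2cc(F)c(F)c(F)c2)Cc2c(N3CC(C#N)CC3=O)cnn21` reaches only a limit of the assay, > 200000 nM. Compound 3 `O=C1CC(c2ccccn2)CN1c1cnn2c1CN(C(=O)Nc1cc(F)c(F)c(F)c1)C(C1CC1)C2` differs from compound 1 in one place: pyridin-2-yl in place of trifluoromethyl on a saturated ring carbon. For the measured compounds named here, no measured step between two compounds is available, so the size of this change is uncertain; a modest step in either direction, or none beyond the scatter, is expected. Compound 3 is therefore estimated to give 100000 nM, between 40000 nM and 200000 nM. This estimate corresponds to an expected step of a 1.2-fold lower number from compound 1 to compound 3 (0.06 log units; within the scatter).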

Compound 3, half-maximal cytotoxic concentration: 96200 nM
The estimate for compound 3 lay 1.0-fold (0.02 log units) above the measured number; the measured number falls inside the stated range.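

In this assay, putting pyridin-2-yl in place of trifluoromethyl on this saturated ring carbon gives a 1.2-fold lower number from compound 1 to compound 3 (0.08 log units; within the scatter), which is within the scatter. Among the compounds shown here, this is the only step that can be read at this position, and it shows that a six-membered aromatic ring carrying a hydrogen-bond acceptor and trifluoromethyl cannot be told apart here. Nothing shown bears on a cause for this result.

As far as these compounds go, whether an amine, a carboxylic acid or a longer alkyl chain on this carbon would give a step beyond the scatter remains open.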